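This account rests on a few compounds, and the source may have more. Where it says the series, first, only, none or still open, it means among the compounds named here.

Measured so far:
Compound 1 `C[C@@]1(c2ccc(OC(F)(F)F)cc2)C[C@@](O)(c2ccccn2)CO1` gives 1120 nM in an assay on HEK293 cells for antagonist activity at transient receptor potential cation channel subfamily V member 3 (Homo sapiens), read by FLIPR and calcium flux; a lower number here means a stronger inhibitor, a higher number a weaker inhibitor.
Compound 2 `OC(c1ccc(F)cn1)C1(c2ccc(Cl)c(Cl)c2)CCC1` gives 910 nM in this assay.

Only these two numbers exist, both from this assay. They lie within the usual scatter of each other, so the results do not separate compound 2 from compound 1: compound 2 stands alongside compound 1, not apart from it.

The next compound, compound 3 `OC(c1cc(F)ccn1)C1(c2ccc(Cl)c(Cl)c2)CCC1`, keeps every atom of compound 2 but joins them differently: 4-fluoropyridin-2-yl in place of 5-fluoropyridin-2-yl on a saturated chain carbon bound to an oxygen on a saturated carbon and a saturated ring carbon. The ring that carries the fluorine is the same kind of ring with the same count of atoms, donors and acceptors, and it sits in the same place on the core of compound 2.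

For the measured compounds named here, no pair of measured compounds shows a change of this kind, so there is no measured step to lean on. With the atom count, the ring type and the attachment point unchanged, the expected step is small: a 1.0-fold lower number from compound 2 to compound 3 (0.00 log units; within the scatter) is expected to stay within the scatter, in no particular direction. Compound 3 is therefore estimated at 900 nM, with a range from 350 nM to 2500 nM.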

Compound 3, antagonist equilibrium constant: 640 nM
Compound 3: the middle estimate sits 1.4-fold (0.15 log units) above what was measured; low and high end bracket the measured number.
By their numbers in this assay, from the lowest: compounds 3, 2 and 1 (each within the scatter of the next).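

Swapping 5-fluoropyridin-2-yl for 4-fluoropyridin-2-yl gives the first measured step at this place, on a saturated chain carbon bound to an oxygen on a saturated carbon and a saturated ring carbon: in this assay it is a 1.4-fold lower number from compound 2 to compound 3 (0.15 log units; within the scatter). The step does not separate the two compounds, so on this evidence the fluorine can sit at either of these two ring places without a difference that the assay can resolve. No supporting data bear on this result.

The compounds shown leave open what a different group on that ring would do, such as a methoxy group, a nitrile or an amine in place of the fluorine. For the compounds shown here, they also leave open what the hydroxyl on the chain carbon contributes, a question that a compound carrying a ketone carbonyl or an amine at that carbon could address, and compound 1 differs from the others in more than one place, so it offers no step to read here.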